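The source may hold more compounds than are shown below. What is called first, only, known or untested is meant among the compounds shown, and "the series" means these compounds.

Compound 1 `COC(=O)[C@@]1(C)CCC=C2[C@@H]1CC[C@@H](C)[C@]2(C)Cc1c[nH]c2c(C)cccc12` and compound 2 `COC(=O)[C@@]1(C)CCC=C2[C@@H]1CC[C@@H](C)[C@]2(C)Cc1c[nH]c2c(Br)cccc12` share one core. In a functional assay on HBL-100 cells (Homo sapiens) for inhibition, read by sulforhodamine B assay, with a stated time of 48 h (on this read-out lower numbers stand for stronger inhibition of growth and higher numbers for weaker inhibition of growth), compound 1 gives 8000 nM and compound 2 gives 18000 nM. The change between them is bromo in place of methyl on an aromatic carbon and it made a 2.3-fold higher number from compound 1 to compound 2 (0.35 log units; beyond the scatter). Compound 3 `COC(=O)[C@@]1(C)CCC=C2[C@@H]1CC[C@@H](C)[C@]2(C)Cc1c(C)[nH]c2ccc(C)cc12` rests on a different core; how its core differs from the core of compound 1 is not broken down here. In this assay compound 3 gives 25000 nM. Compound 4 `COC(=O)[C@@]1(C)CCC=C2[C@@H]1CC[C@@H](C)[C@]2(C)Cc1c(C)[nH]c2ccc(Br)cc12` is derived from compound 3 by bromo in place of methyl on an aromatic carbon. This is the same kind of change as the one seen earlier, though the place differs: in compound 2 the bromo is ortho to a fused ring and meta to a fused ring, whereas in compound 4 it is meta to a fused ring and para to a fused ring. On the strength of that single earlier step, compound 4 is expected to show a 1.8-fold higher number from compound 3 to compound 4 (0.26 log units; within the scatter) in this assay, much like the earlier step. Compound 4 is therefore estimated at 45000 nM, with a likely range from 20000 nM to 100000 nM.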

Compound 4, concentration for 50% growth inhibition: 15000 nM
For compound 4 the middle estimate is 3.0-fold (0.48 log units) above the measured one, and the stated range ends above it.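

In this assay, bromo in place of methyl on an aromatic carbon gives a 1.7-fold lower number from compound 3 to compound 4 (0.22 log units; within the scatter), so on this core the swap produces no step beyond the scatter. Set beside the earlier step, the change does not carry over as a fixed amount from one core to the other: the same change on two cores in this assay, a 2.3-fold higher number (0.35 log units; beyond the scatter) from compound 1 to compound 2 and a 1.7-fold lower number (0.22 log units; within the scatter) from compound 3 to compound 4, 3.8-fold (0.57 log units) apart, beyond the scatter of two such steps. Within the data shown here, only two pairs stand behind this, and they differ both in core and in where the bromo sits, so the data do not show which of the two separates the steps.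

The compounds shown leave open how a chloro group or a methoxy group on the same aromatic carbons would compare. They also leave open what a carboxylic acid in place of the methyl ester would do to growth inhibition.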